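The Same Methyl Step, Carried onto a Second Core

This account rests on a few compounds, and the source may have more. Where it says the series, first, only, none or still open, it means among the compounds named here.

Measured so far:
compound 1 `COc1cc2c(Nc3ccc(C#N)cc3)ncnc2cc1OCCCN1CCN(C)CC1` gives 13000 nM in a functional assay on SH-SY5Y cells (Homo sapiens) for antiproliferative activity, read by MTT assay, with a stated time of 72 h; a lower number here means a stronger inhibitor, a higher number a weaker inhibitor;
compound 2 `CCN1CCN(CCCOc2cc3ncnc(Nc4ccc(C#N)cc4)c3cc2OC)CC1` gives 5440 nM;
compound 3 `COc1cc2c(Nc3cccc(C#N)c3)ncnc2cc1OCCCN1CCN(C)CC1` gives 6890 nM.

Compound 2 differs from compound 1 by methyl in place of hydrogen on a saturated chain carbon bound to an amine nitrogen in a ring, and that change brought a 2.4-fold lower number from compound 1 to compound 2 (0.38 log units; beyond the scatter). Compound 3 differs from compound 1 in its core by 3-cyanophenyl in place of 4-cyanophenyl on a nitrogen on an aromatic ring, a step of a 1.9-fold lower number from compound 1 to compound 3 (0.28 log units; within the scatter). Compound 4 `CCN1CCN(CCCOc2cc3ncnc(Nc4cccc(C#N)c4)c3cc2OC)CC1` now carries the same change onto compound 3, namely (methyl in place of hydrogen on a saturated chain carbon bound to an amine nitrogen in a ring), at the same place as before.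

The account expects compound 4 to follow compound 3 by a step of a 2.2-fold lower number from compound 3 to compound 4 (0.33 log units; beyond the scatter), because the earlier change gave a 2.4-fold lower number from compound 1 to compound 2 (0.38 log units; beyond the scatter) and the two cores differ only by 3-cyanophenyl in place of 4-cyanophenyl on a nitrogen on an aromatic ring. Compound 4 is therefore estimated at 3200 nM, with a range from 1500 nM to 7500 nM.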

Compound 4, half-maximal inhibitory concentration: 6270 nM
Beside the measured number, compound 4's estimate is 2.0-fold (0.29 log units) below it, within the range that was stated.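

In this assay, methyl in place of hydrogen on a saturated chain carbon bound to an amine nitrogen in a ring gave a 1.1-fold lower number from compound 3 to compound 4 (0.04 log units; within the scatter), and this step cannot be told apart from the one on the first core: the same change on two cores in this assay, a 2.4-fold lower number (0.38 log units; beyond the scatter) from compound 1 to compound 2 and a 1.1-fold lower number (0.04 log units; within the scatter) from compound 3 to compound 4, 2.2-fold (0.34 log units) apart, within the scatter of two such steps. The exchange of 3-cyanophenyl for 4-cyanophenyl gave a 1.2-fold higher number from compound 2 to compound 4 (0.06 log units; within the scatter), and it too reads alike on both cores: the same change on two cores in this assay, a 1.9-fold lower number (0.28 log units; within the scatter) from compound 1 to compound 3 and a 1.2-fold higher number (0.06 log units; within the scatter) from compound 2 to compound 4, 2.2-fold (0.34 log units) apart, within the scatter of two such steps. These two pairs therefore show no measurable difference between the cores, but they do not establish that the methyl step transfers as a rule, since it lies beyond the scatter on one core and within it on the other.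

The compounds shown leave open how a propyl group in place of the ethyl of compound 4 would read in this assay. They also leave open what a carboxylic acid in place of the nitrile would give.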